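Cytotoxicity limit in the fluoro to chloro step

A few compounds are considered here, and "the series" means these few. Any claim that something is new, unique, unknown or untested is made for them only; others in the source may bear on it.

Measured in a toxicity assay on Huh-7 cells (Homo sapiens) for cytotoxicity, read by CCK-8 assay, with a stated time of 24 h; a lower number here means that less compound is tolerated, a higher number that more compound is tolerated:
- compound 1 (`O=c1cc(-c2ccccc2)oc2c(-c3cccc(F)c3)c(O)c(O)c(O)c12`): > 100000 nM (a limit)
- compound 2 (`O=c1cc(-c2ccc(Nc3ccc(F)cc3)cc2)oc2cc(O)c(O)c(O)c12`): > 100000 nM (a limit)
- compound 3 (`Oc1c(O)c(O)c2c(=S)cc(-c3ccccc3)oc2c1-c1ccc(F)cc1`): > 100000 nM (a limit)

Compound 2 gives no number in this assay, only the limit > 100000 nM (not a measured value). For the measured compounds named here, the whole series so far stands at the limit of > 100000 nM in this assay, at which 3 of the 3 values shown sit, so compound 2 cannot be placed relative to compound 1 or compound 3.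

Compound 4 (`O=c1cc(-c2ccc(Nc3ccc(Cl)cc3)cc2)oc2cc(O)c(O)c(O)c12`) differs from compound 2 in one place (chloro in place of fluoro on an aromatic carbon), with chloro in place of fluoro on an aromatic carbon, para to a large group.

Going by the values given here, no step between measured compounds is available to scale from. No shift beyond the scatter is expected in this assay, and no direction can be assigned. Among the compounds with values here, this expectation rests on compound 2 and its limit of > 100000 nM as the only close neighbour.

The expected step is a number no higher from compound 2 to compound 4 (the limit leaves the size open) in this read-out.

Compound 4 is estimated at 100000 nM, with an expected range of 50000 nM to 200000 nM, and is likely to be reported only as a limit again.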

Compound 4, half-maximal cytotoxic concentration: > 100000 nM
Compound 4 was reported as a limit (the forecaster's own chance of this, stated with the estimate: 80%); the middle value sits exactly at the limit.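

Compound 2 and compound 4 are both reported only as limits in this assay, so no step between them can be read: the limit of > 100000 nM in this assay, at which 4 of the 4 values shown sit.

The compounds shown leave open how chloro and fluoro compare here, and what cytotoxic concentration any of these compounds actually has.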